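Solubility notes: amine swap toward compound 4

A few compounds are considered here, and "the series" means these few. Any claim that something is new, unique, unknown or untested is made for them only; others in the source may bear on it.

Measured so far in a physicochemical assay for solubility, read by spectrophotometry, in phosphate buffer, with a stated time of 2 h, at pH 7.4; a lower number here means a less soluble compound, a higher number a more soluble compound:
- compound 1, `COc1ccc2[nH]c(C(=O)N3CC(=O)N(Cc4ccccc4)[C@@H](CN4CCCCC4)C3)cc2c1`: > 25000 nM
- compound 2, `COc1ccc2[nH]c(C(=O)N3CC(=O)N(Cc4ccccc4)[C@@H](Cc4ccccn4)C3)cc2c1`: > 100000 nM
- compound 3, `COc1ccc2[nH]c(C(=O)N3CC(=O)N(Cc4cccc(OC(F)F)c4)[C@@H](CN4CCCCC4)C3)cc2c1`: 26400 nM

The value of compound 1 in this assay is a limit, not a number. The value of compound 2 in this assay is likewise a limit. Among the measured compounds shown here, compound 3 is therefore the only compound of the three with a read number in this assay; the two other values shown are limits.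

Compound 4, `COc1ccc2[nH]c(C(=O)N3CC(=O)N(Cc4cccc(OC(F)F)c4)[C@@H](CN4CCN(C5CC5)CC4)C3)cc2c1`, is not yet measured in this assay. It differs from compound 3 in one place: 4-cyclopropylpiperazin-1-yl in place of piperidin-1-yl on a saturated chain carbon bound to a saturated ring carbon.

Two measured steps exist. The step that the two limits leave unreadable from compound 1 to compound 2 cannot be sized, the two limits leaving it unreadable. The step that the limit leaves unreadable from compound 1 to compound 3 is likewise unreadable, one limit hiding its size. For the measured compounds named here, neither step bears on the exchange of one saturated amine for another on the chain, and no measured pair shows such a change. From compound 3 as the single anchor, compound 4 is expected near it, with a wide range: estimated 40000 nM (12000 nM to 130000 nM), a step of a 1.5-fold higher number from compound 3 to compound 4 (0.18 log units; within the scatter) expected within the scatter.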

Compound 4, solubility: 99600 nM
Compound 4: the middle estimate sits 2.5-fold (0.40 log units) below what was measured; low and high end bracket the measured number.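

In this assay, among the compounds shown here, 4-cyclopropylpiperazin-1-yl in place of piperidin-1-yl on a saturated chain carbon bound to a saturated ring carbon gives the first sized exchange of one saturated amine for another at this place, a 3.8-fold higher number from compound 3 to compound 4 (0.58 log units; beyond the scatter), and the read-out at this place therefore responds to the choice of amine, at least in this one pair. For the compounds shown here, the steps starting from compound 1 cannot be read, so this remains the only sized step in the set. Nothing shown gives a cause for this step. Still open, going by these compounds, is whether the step follows the piperazine ring or its cyclopropyl group, which a plain piperazin-1-yl or a morpholin-4-yl at the same place could help separate. Also open, on these data alone, is whether the same exchange gives a step of similar size on a core without the difluoromethoxy group.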